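Another Methoxy Group Added to Compound 3

A few compounds are considered here, and "the series" means these few. Any claim that something is new, unique, unknown or untested is made for them only; others in the source may bear on it.

Of the compounds shown here, three have been measured in a functional assay for inhibition, with a stated time of 30 min, tested at 1 mM; a higher number here means more inhibition at the concentration tested (going by the name of the read-out), a lower number less inhibition. Compound 1 `COc1ccc(/C(Cl)=C/C=C(\C#N)C(=O)c2c[nH]c3ccccc23)cc1` gives 23.4%. Compound 2 `COc1ccc(/C(Cl)=C/C=C(\C#N)C(=O)c2c[nH]c3ccc(OC)cc23)cc1` gives 16.7% in this assay; it differs from compound 1 by methoxy in place of hydrogen on an aromatic carbon, and the step of a number 6.7 percentage points lower from compound 1 to compound 2 (within the scatter). Compound 3 `COc1ccc(/C(Cl)=C/C=C(\C#N)C(=O)c2c(C)[nH]c3ccccc23)cc1OC` gives 22.4% in this assay; the difference between its core and that of compound 1 is not broken down here, and its value sits close to those of compound 1 and compound 2.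

Compound 4 `COc1cc(/C(Cl)=C/C=C(\C#N)C(=O)c2c(C)[nH]c3ccccc23)cc(OC)c1OC` has not yet been measured. It differs from compound 3 by methoxy in place of hydrogen on an aromatic carbon. For the measured compounds named here, this is the same kind of change as the one from compound 1 to compound 2, but not the same: in compound 2 the new group sits on a ring that is part of a fused or bridged system of two rings, meta to a fused ring and para to a fused ring, whereas in compound 4 it sits on a six-membered aromatic ring of carbon only, ortho to a methoxy group, meta to a large group and meta to a methoxy group. Going by the values given here, for compound 4 the expected step is a number 4.4 percentage points lower from compound 3 to compound 4 (within the scatter), a small one, because the only measured step of this kind a number 6.7 percentage points lower from compound 1 to compound 2 (within the scatter) stayed within the scatter. That expectation rests on a single pair and on a change at a different place. The estimate for compound 4 in this assay is 18%, with a range from 6% to 30%.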

Compound 4, a percentage reported as inhibition, at one concentration (the size of the read-out at that concentration, not a potency): 14.5%
Compound 4: middle estimate off by 3.5 percentage points, on the high side, within the range that was stated.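

In this assay, methoxy in place of hydrogen on an aromatic carbon gives a step of a number 7.9 percentage points lower from compound 3 to compound 4 (within the scatter). Set beside the earlier step, the same change reads alike on the two cores: the same change on two cores in this assay, a number 6.7 percentage points lower (within the scatter) from compound 1 to compound 2 and a number 7.9 percentage points lower (within the scatter) from compound 3 to compound 4, 1.2 percentage points apart, within the scatter of two such steps. This shows that the two available steps agree in size, but each stays within the scatter, so neither establishes a real effect of the methoxy group, and two pairs with the group at different places give no rule for carrying the change to other cores in this series.

The compounds shown leave open how a group other than methoxy, such as an amine or a carboxylic acid, would read in this assay on the same aromatic carbon. They also leave open whether a methoxy group at other places on these rings would give a step that clearly exceeds the scatter.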